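A few compounds are considered here, and "the series" means these few. Any claim that something is new, unique, unknown or untested is made for them only; others in the source may bear on it.

In an assay on L1.2 cells for binding affinity to C-C chemokine receptor type 8 (Homo sapiens) (on this read-out higher numbers stand for weaker inhibition and lower numbers for stronger inhibition), the three measured compounds spread widely. Compound 1 `CN1CCN(S(=O)(=O)c2ccc(NC(=O)c3ccccc3)c3ccccc23)CC1` gives > 30000 nM, which is a limit of the assay rather than a number; this is the limit of > 30000 nM in this assay, at which 1 of the 3 values shown sits. Compound 2 `CCOC(=O)N1CCC(NS(=O)(=O)c2ccc(C(=O)Nc3ccccc3C)c3ccccc23)CC1` gives 5.21 nM in this assay. Compound 3 `CCC(=O)N1CCC(NS(=O)(=O)c2ccc(NC(=O)c3ccccc3C)c3ccccc23)CC1` gives 2.5 nM in this assay, the lowest of the two numbers shown, with compound 2 as its nearest neighbour at a gap beyond the scatter.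

Compound 4 `CC(=O)N1CCC(NS(=O)(=O)c2ccc(NC(=O)c3ccccc3C)c3ccccc23)CC1` differs from compound 3 in one place: hydrogen in place of methyl on a saturated chain carbon bound to a carbonyl carbon, so the propanoyl on the piperidine becomes an acetyl while the rest of the molecule stays as in compound 3. Within the data shown here, no measured pair here shows such a shortening of the acyl chain, so the expectation rests on the small size of the change. A shift within the scatter of this assay is expected in either direction, without a clear preference. The estimate for compound 4 in this assay is 3 nM, between 1.2 nM and 8 nM, which is a step of a 1.2-fold higher number from compound 3 to compound 4 (0.08 log units; within the scatter) expected from compound 3.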

Compound 4, inhibition constant: 6.7 nM
Compound 4: middle estimate off by 2.2-fold (0.35 log units), on the low side; measured number inside the range.
By their numbers in this assay, from the lowest: compound 3; then compounds 2 and 4 (each within the scatter of the next). At a limit, above all of these: compound 1.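

Shortening the propanoyl on the piperidine to an acetyl is the first change in this series that can be read at a single place, and in this assay it gives a 2.7-fold higher number from compound 3 to compound 4 (0.43 log units; beyond the scatter). The position therefore responds to the loss of one methyl on a saturated chain carbon bound to a carbonyl carbon, though only modestly, and compound 4 still gives a measured number rather than a limit. Nothing shown here accounts for this step.

With only the propanoyl and the acetyl compared directly at this place, a single step gives no trend along the chain. From the compounds shown here alone, it remains open whether a longer chain such as butanoyl would lower the number further, and how an amine or a carboxylic acid at the end of the acyl chain would read.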